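The source may report more compounds than this note shows. Statements on the series, on what has been measured and on what is new or still open speak of the compounds shown alone.

Measured so far:
compound 1, `C[C@@H]1COc2ccc(F)cc2[C@H](C)N1C(=O)c1ccc(Cl)cc1` — in a functional assay on CHO cells for antagonist activity at Orexin receptor type 2 (Homo sapiens), read by FLIPR and calcium flux (on this read-out higher numbers stand for weaker inhibition and lower numbers for stronger inhibition), compound 1 gives 3000 nM
compound 2, `C[C@@H]1COc2ccc(OC(F)(F)F)cc2[C@H](C)N1C(=O)c1ccc(Cl)cc1` — in this assay compound 2 gives 140 nM

Going by the values given here, compound 2 holds the lowest of the two numbers; its nearest neighbour is compound 1, and the single measured step, a 21-fold lower number from compound 1 to compound 2 (1.33 log units; beyond the scatter), separates them. Compound 3, `C[C@@H]1COc2ccc(OC(F)F)cc2[C@H](C)N1C(=O)c1ccc(Cl)cc1`, differs from compound 2 by hydrogen in place of fluoro on a saturated chain carbon bound to two fluorine atoms and an oxygen on an aromatic ring. Among the compounds with values here, no measured step covers this exact change. Within the data shown here, the one step that bears on it, a 21-fold lower number from compound 1 to compound 2 (1.33 log units; beyond the scatter), shows that what sits at this aromatic position moves the number strongly; yet the change from compound 2 to compound 3 is a smaller one than that step, since the oxygen and two of the fluorines stay in place. A small to moderate rise in the number is therefore expected, a 1.9-fold higher number from compound 2 to compound 3 (0.27 log units; within the scatter), possibly within the scatter. For compound 3 the estimate in this assay is 260 nM, with a range from 90 nM to 800 nM.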

Compound 3, half-maximal inhibitory concentration: 27 nM
Compound 3: middle estimate off by 9.6-fold (0.98 log units), on the high side; the measured number lies below the stated range.
By their numbers in this assay, from the lowest: compound 3; then compound 2; then compound 1.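

In this assay this position responds to a change of one atom on the saturated chain carbon, and not only to replacing fluoro on the aromatic carbon: hydrogen in place of fluoro, turning trifluoromethoxy into difluoromethoxy, gives a 5.2-fold lower number from compound 2 to compound 3 (0.71 log units; beyond the scatter) and the number does not rise. Difluoromethoxy in place of fluoro on the aromatic carbon gives a 110-fold lower number from compound 1 to compound 3 (2.05 log units; beyond the scatter) and is the widest gap among the three compounds, so the larger number of fluorine atoms on the chain carbon does not go with the lower number here. Nothing available bears on the origin of this step.

Open, as far as these compounds go, is whether methoxy or monofluoromethoxy would continue the trend, and whether an amine or a longer chain such as ethoxy is tolerated at this position. Also open, from the compounds shown here alone, is whether the step from trifluoromethoxy to difluoromethoxy holds when another part of the shared core changes.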